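A few compounds are considered here, and "the series" means these few. Any claim that something is new, unique, unknown or untested is made for them only; others in the source may bear on it.

Measured compounds in hand:
- compound 1, `CCCCCc1ccc(-c2cn(-c3cccc(C(=O)/C=C/c4ccc(O)c(OC)c4)c3)nn2)cc1`: 5780 nM
- compound 2, `COc1cc(/C=C/C(=O)c2cccc(-n3cc(-c4ccccc4C(F)(F)F)nn3)c2)ccc1O`: 5070 nM
- compound 3, `COc1cc(/C=C/C(=O)c2cccc(-n3cc(-c4ccc(Br)cc4)nn3)c2)ccc1O`: 19100 nM

In a functional assay on RAW264.7 cells (Mus musculus) for inhibition, with a stated time of 4 days (on this read-out higher numbers stand for weaker inhibition and lower numbers for stronger inhibition), the three measured compounds differ only in the aryl group carried on the triazole. Compound 3 has the highest number of the three, and the steps of a 3.3-fold higher number from compound 1 to compound 3 (0.52 log units; beyond the scatter) and a 3.8-fold higher number from compound 2 to compound 3 (0.58 log units; beyond the scatter) are both beyond the scatter, so it is the weakest inhibitor measured. Compound 1 and compound 2 cannot be ordered, since a 1.1-fold lower number from compound 1 to compound 2 (0.06 log units; within the scatter) lies within the scatter.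

Compound 4, `COc1ccc(/C=C/C(=O)c2cccc(-n3cc(-c4ccc(Br)cc4)nn3)c2)cc1O`, keeps the aryl group of compound 3 on the triazole and changes the other end of the molecule instead: 3-hydroxy-4-methoxyphenyl in place of 4-hydroxy-3-methoxyphenyl on a double-bonded chain carbon bound to a double-bonded chain carbon. For the measured compounds named here, none of the measured steps touches this part of the structure, so no measured step bears on the change, and there is no basis for expecting a step in this assay beyond the scatter in either direction. Compound 4 is therefore estimated at 19000 nM, with a range from 8000 nM to 45000 nM. The step of a 1.0-fold lower number from compound 3 to compound 4 (0.00 log units; within the scatter) is an estimate only and is expected to stay within the scatter.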

Compound 4, half-maximal inhibitory concentration: 6570 nM
Beside the measured number, compound 4's estimate is 2.9-fold (0.46 log units) above it; measured number outside the range, below it.
By their numbers in this assay, from the lowest: compounds 2, 1 and 4 (each within the scatter of the next); then compound 3.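

In this assay, 3-hydroxy-4-methoxyphenyl in place of 4-hydroxy-3-methoxyphenyl on a double-bonded chain carbon bound to a double-bonded chain carbon gives a 2.9-fold lower number from compound 3 to compound 4 (0.46 log units; beyond the scatter) with the same atoms joined differently. The earlier compounds shown here varied only the aryl group on the triazole; this pair shows that the read-out also responds to a change at the other end of the molecule, with 4-bromophenyl held constant. No evidence in hand accounts for this step.

From the compounds shown here alone, whether the exchange gives a step of similar size with 4-pentylphenyl or 2-(trifluoromethyl)phenyl on the triazole remains open, as the observation rests on a single pair. Also open, going by these compounds, is how the read-out would respond if an amine or a carboxylic acid took the place of the hydroxy group, or an ethoxy group the place of the methoxy group.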